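This account rests on a few compounds, and the source may have more. Where it says the series, first, only, none or still open, it means among the compounds named here.

Among the compounds with values here, in an assay on isolated protein for inhibition of steroid 5-alpha-reductase (Rattus norvegicus) (on this read-out lower numbers stand for stronger inhibition and higher numbers for weaker inhibition), compound 2 `COc1ccccc1N1CCN(CCC(Oc2ccc(C(=O)Nc3ccccc3OCCCC(=O)O)cc2)c2ccc(CC(C)C)cc2)CC1` gives 39 nM, the lower of the two numbers known so far; compound 1 `COc1ccccc1N1CCN(CCC(Oc2ccc(C(=O)Nc3ccccc3OCCCC(=O)O)cc2)c2ccccc2)CC1` gives 1000 nM. Compound 3 `COc1ccc(C(CCN2CCN(c3ccccc3OC)CC2)Oc2ccc(C(=O)Nc3ccccc3OCCCC(=O)O)cc2)cc1` differs from compound 2 by methoxy in place of isobutyl on an aromatic carbon. Within the data shown here, the only measured step at this position is a 26-fold lower number from compound 1 to compound 2 (1.41 log units; beyond the scatter), a large gain. Since the entering methoxy is the smaller group by the counted heavy atoms, compound 3 is expected to land between the two measured numbers, nearer compound 1. The estimated step is a 7.7-fold higher number from compound 2 to compound 3 (0.89 log units; beyond the scatter). Compound 3 is therefore expected to give about 300 nM, within a range from 80 nM to 1200 nM.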

Compound 3, half-maximal inhibitory concentration: 170 nM
Compound 3: middle estimate off by 1.8-fold (0.25 log units), on the high side; measured number inside the range.
By their numbers in this assay, from the lowest: compound 2; then compound 3; then compound 1.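

In this assay the gain at this position is not confined to isobutyl: methoxy in place of hydrogen gives a 5.9-fold lower number from compound 1 to compound 3 (0.77 log units; beyond the scatter) and so still improves on the unsubstituted ring. Isobutyl nevertheless holds the advantage, since methoxy in its place gives a 4.4-fold higher number from compound 2 to compound 3 (0.64 log units; beyond the scatter) as a loss that keeps only part of that gain. Nothing available explains the difference between these two groups. From the compounds shown here alone, whether the number depends on the size of the group or on its oxygen stays open. An ethoxy group, a tert-butyl group or a longer chain such as n-butyl at this position would help separate the two.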